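This account rests on a few compounds, and the source may have more. Where it says the series, first, only, none or still open, it means among the compounds named here.

Working notes on the series. The shared core is the same throughout; the compounds differ only in the aryl group on the carbon with a double bond to nitrogen. Compound 1 `CCCSc1nc(N/N=C/c2ccc(C)cc2)c2nnn(Cc3ccccc3)c2n1` bears 4-methylphenyl there. In a functional assay on ECa-109 cells (Homo sapiens) for antiproliferative activity, read by MTT assay, with a stated time of 72 h (on this read-out higher numbers stand for weaker inhibition and lower numbers for stronger inhibition), compound 1 returns only a limit, > 64000 nM. Compound 2 `CCCSc1nc(N/N=C/c2c(O)ccc3ccccc23)c2nnn(Cc3ccccc3)c2n1` carries 2-hydroxynaphthalen-1-yl, and in this assay compound 2 gives 9290 nM. Compound 3 `CCCSc1nc(N/N=C/c2ccc([N+](=O)[O-])cc2)c2nnn(Cc3ccccc3)c2n1` carries 4-nitrophenyl, and in this assay compound 3 gives 6640 nM, the lowest of the two numbers measured, though the step of a 1.4-fold lower number from compound 2 to compound 3 (0.15 log units; within the scatter) lies within the scatter. Both aryl changes away from compound 1 moved the read-out: an at least 6.8-fold lower number from compound 1 to compound 2 (0.83 log units; beyond the scatter) and an at least 9.6-fold lower number from compound 1 to compound 3 (0.98 log units; beyond the scatter).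

Compound 4 `CCCSc1nc(N/N=C/c2ccc3ccccc3c2)c2nnn(Cc3ccccc3)c2n1` is the next step: naphthalen-2-yl in place of 4-nitrophenyl on a carbon with a double bond to nitrogen. Going by the values given here, the steps that bear on it are an at least 9.6-fold lower number from compound 1 to compound 3 (0.98 log units; beyond the scatter), since the nitro group that entered there now leaves, and an at least 6.8-fold lower number from compound 1 to compound 2 (0.83 log units; beyond the scatter), which shows that a second fused ring without nitro can still give a number, though compound 2 also carries a hydroxy group and compound 4 carries none. A higher number of modest size is expected for compound 4, a 3.0-fold higher number from compound 3 to compound 4 (0.48 log units; beyond the scatter). The estimate for compound 4 in this assay is 20000 nM, between 6000 nM and 64000 nM, with a fair chance that only a limit is returned.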

Compound 4, half-maximal inhibitory concentration: > 64000 nM
Compound 4: no number, only a limit; the forecaster's own chance of this, stated with the estimate: 30%; middle value at least 3.2-fold (0.50 log units) away from the limit.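

In this assay, naphthalen-2-yl in place of 4-nitrophenyl gives an at least 9.6-fold higher number from compound 3 to compound 4 (0.98 log units; beyond the scatter), so on the carbon with a double bond to nitrogen a larger aryl group with a second fused ring does not keep the read-out that the nitro-bearing group gave. Naphthalen-2-yl in place of 2-hydroxynaphthalen-1-yl gives an at least 6.8-fold higher number from compound 2 to compound 4 (0.83 log units; beyond the scatter), which shows that two fused rings alone are not enough for a measurable number at this position and that the difference lies in the hydroxy group, the point of attachment of the fused rings, or both. The steps linking compound 1 and compound 4 cannot be read, because both stand at a limit and not at a number: the limit of > 64000 nM in this assay, at which 2 of the 4 values shown sit.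

The compounds shown do not separate the contribution of the hydroxy group from that of the attachment point, as both change in the single step to 2-hydroxynaphthalen-1-yl. On these data alone, it also remains open how an amine or a carboxylic acid in place of the nitro group on the phenyl ring would read in this assay.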